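A few compounds are considered here, and "the series" means these few. Any claim that something is new, unique, unknown or untested is made for them only; others in the source may bear on it.

Working notes on the series in an assay on cells (1-87 tumor cell line) for inhibition of Polyunsaturated fatty acid 5-lipoxygenase (Homo sapiens), with a stated time of 5 min; a higher number here means a weaker inhibitor, a lower number a stronger inhibitor.

Three compounds carry numbers. Compound 1 `O=C1CCCCC1C1CC(=O)N(Cc2ccccc2)C1=O` gives 36000 nM, and compound 3 `O=C1CCCC1C1CC(=O)N(c2ccccc2)C1=O` gives 98600 nM. Compound 2 `Cc1ccc(C(=O)CC2CC(=O)N(c3ccc(S(N)(=O)=O)cc3)C2=O)cc1` gives 860 nM, the lowest of the three numbers; the gaps from compound 2 to compound 1 and to compound 3 both lie beyond the scatter, so compound 2 is the strongest inhibitor of the measured set. Among the compounds with values here, no two measured compounds differ in a single place, so no step within the set can be read directly.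

Compound 4 `COc1ccc(C(=O)CC2CC(=O)N(c3ccc(S(N)(=O)=O)cc3)C2=O)cc1` differs from compound 2 in one place: methoxy in place of methyl on an aromatic carbon. Within the data shown here, the measured compounds offer no step that bears on this change, so the expectation rests on compound 2 alone. A small step is expected, with no clear direction, of the size a 1.0-fold higher number from compound 2 to compound 4 (0.02 log units; within the scatter), which is within the scatter. For compound 4 the estimate in this assay is 900 nM, with a range from 300 nM to 2700 nM.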

Compound 4, half-maximal inhibitory concentration: 4740 nM
Compound 4: the middle estimate sits 5.3-fold (0.72 log units) below what was measured, and the stated range ends below it.
By their numbers in this assay, from the lowest: compound 2; then compound 4; then compound 1; then compound 3.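

In this assay, within the data shown here, the change from 4-methylphenyl to 4-methoxyphenyl gives a 5.5-fold higher number from compound 2 to compound 4 (0.74 log units; beyond the scatter) and is the first step that can be read directly. It shows that this position, on the aromatic ring para to a large group, is not indifferent to what it carries: of the two groups, methyl goes with the stronger inhibitor. The data include no measurement that would account for this step.

As far as these compounds go, only methyl and methoxy are available for comparison at this position, so it remains open how a chlorine, a hydroxyl or an ethyl group would rank against them. Among these compounds, it is also open whether the same change would give a similar step on another core, since no other pair carries it.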